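A few compounds are considered here, and "the series" means these few. Any claim that something is new, unique, unknown or untested is made for them only; others in the source may bear on it.

Compound 1 `COc1ccc(C2=C(c3cc(OC)c(OC)c(OC)c3)C(=O)CC2O[SiH2]C(C)(C)C)cc1OC`: in this assay a limit, > 100 ug/mL
Compound 2 `COC(=O)c1cc(C2=C(c3cc(OC)c(OC)c(OC)c3)C(=O)CC2O[SiH2]C(C)(C)C)ccc1OC`: a limit, > 100 ug/mL
Compound 3 `COc1cc(C2=C(c3ccccc3)C(O[SiH2]C(C)(C)C)CC2=O)cc(OC)c1OC`: a limit, > 100 ug/mL

In an ADME assay on KB cells (Homo sapiens) for cytotoxicity, read by MTT assay, with a stated time of 72 h (on this read-out higher numbers stand for weaker inhibition and lower numbers for stronger inhibition), none of the three measured compounds gives a number. Compound 3 stands at the same limit of the assay as the other two, which is recorded as the limit of > 100 ug/mL in this assay, at which 3 of the 3 values shown sit. Every step between the measured compounds is therefore unreadable: a step that the two limits leave unreadable from compound 1 to compound 2, a step that the two limits leave unreadable from compound 1 to compound 3 and a step that the two limits leave unreadable from compound 2 to compound 3 each say only that both ends sit at the limit.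

Compound 4 `COc1ccc(C2=C(c3cc(OC)c(OC)c(OC)c3)C(=O)CC2O[SiH2]C(C)(C)C)cc1` differs from compound 3 by methoxy in place of hydrogen on an aromatic carbon. Of the measured steps, the one closest in kind is a step that the two limits leave unreadable from compound 1 to compound 3, where a larger change on the same double-bonded ring carbon left both compounds at the limit; the two others likewise give no readable size. Within the data shown here, no measured step therefore points to a change beyond the scatter in either direction, and the step that the limit leaves unreadable from compound 3 to compound 4 is expected to be no larger than the scatter. Compound 4 is estimated to give 150 ug/mL, with a range from 60 ug/mL to 400 ug/mL, most probably reported again only as a limit.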

Compound 4, half-maximal inhibitory concentration: > 100 ug/mL
Compound 4: no number, only a limit; the forecaster's own chance of this, stated with the estimate: 85%; the middle value lies beyond the limit too.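

In this assay, among these compounds, compound 4 gives > 100 ug/mL, again a limit and not a number, so no step from compound 1, compound 2 or compound 3 to compound 4 can be read: the limit of > 100 ug/mL in this assay, at which 4 of the 4 values shown sit. The compounds shown leave open whether any of these group changes on the shared core alters the read-out at all.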